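Aryl amide swaps: from compound 3 to compound 4

This account rests on a few compounds, and the source may have more. Where it says the series, first, only, none or still open, it means among the compounds named here.

In a functional assay on T47D cells (Homo sapiens) for inhibition, read by CCK-8 assay, with a stated time of 72 h, tested at 10 uM (a higher number here means more inhibition of growth at the concentration tested, a lower number less inhibition of growth), compound 1 `CN(C)C(=O)c1cc2cnc(Nc3ccc(NC(=O)C4(C(=O)Nc5ccc(F)cc5)CC4)cc3)nc2n1C1CCCC1` reads 105% and compound 2 `CN(C)C(=O)c1cc2cnc(Nc3ccc(NC(=O)C4(C(=O)Nc5ccc(Br)cc5)CC4)cc3)nc2n1C1CCCC1` reads 94.3% while compound 3 `COc1cccc(NC(=O)C2(C(=O)Nc3ccc(Nc4ncc5cc(C(=O)N(C)C)n(C6CCCC6)c5n4)cc3)CC2)c1` reads 93.5% on the same shared core. The step of a number 0.8 percentage points lower from compound 2 to compound 3 (within the scatter) leaves no separation, and the step of a number 11.5 percentage points lower from compound 1 to compound 3 (beyond the scatter) is matched in size by the step of a number 10.7 percentage points lower from compound 1 to compound 2 (beyond the scatter) in this small set. Compound 3 thus stands level with the bromo analogue and under the fluoro analogue.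

The change to compound 4 `CN(C)C(=O)c1cc2cnc(Nc3ccc(NC(=O)C4(C(=O)Nc5ccc(C(F)(F)F)cc5)CC4)cc3)nc2n1C1CCCC1` places 4-(trifluoromethyl)phenyl in place of 3-methoxyphenyl on an amide-type nitrogen. Among the compounds with values here, no measured step makes this exact exchange, and no measured compound carries trifluoromethyl. The nearest evidence is the two steps that end at compound 3, each starting from a 4-substituted phenyl. Compound 2 (94.3%) shows no gap to compound 3, whereas compound 1 (105%) shows a modest one. With only these two cases, compound 2 is the closer guide, and a small upward move is the most that is expected.

The expected change is a number 2.5 percentage points higher from compound 3 to compound 4 (within the scatter) and is not expected to clear the scatter. In this assay compound 4 is estimated at 96% with a range from 84% to 107% expected.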

Compound 4, percent growth inhibition at one concentration: 94.9%
Beside the measured number, compound 4's estimate is 1.1 percentage points above it; the measured number falls inside the stated range.
By their numbers in this assay, from the lowest: compounds 3, 2 and 4 (each within the scatter of the next); then compound 1.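

In this assay, the exchange on the amide-type nitrogen gives a number 1.4 percentage points higher from compound 3 to compound 4 (within the scatter), and trifluoromethyl in place of bromo gives a number 0.6 percentage points higher from compound 2 to compound 4 (within the scatter), so this position now holds a third group that stands level with the other two, even though the hydrogen-bond acceptor counted on 3-methoxyphenyl is absent from 4-(trifluoromethyl)phenyl. Trifluoromethyl in place of fluoro gives a number 10.1 percentage points lower from compound 1 to compound 4 (beyond the scatter), which leaves compound 1 as the one member of the set apart from the rest, so the level reading holds only for compound 2, compound 3 and compound 4, with compound 1 going against it. No measured information on these compounds accounts for either the level standing of the three or the separation of compound 1.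

Every group shown at this position is a substituted phenyl, so the outcome with a phenyl carrying an amine or a carboxylic acid, or with a saturated cyclohexyl ring in its place, remains open. Also open, on these data alone, is whether compound 2, compound 3 and compound 4 would stay level in this assay at a lower test concentration.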